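The compounds below may be only part of what the source reports. "The series", "measured", "known", "first", "only" and "open" are said of these compounds alone.

Measured in a functional assay on MKN-45 cells (Homo sapiens) for inhibition, read by MTT assay, with a stated time of 72 h; on this read-out lower numbers stand for stronger inhibition and higher numbers for weaker inhibition:
compound 1 `COc1cc2c(Oc3ccc(NC(=O)c4nn(-c5ccccc5C)c(=O)cc4C)cc3F)ccnc2cc1OCCCN1CCN(C)CC1` gives 1630 nM
compound 2 `COc1cc2c(Oc3ccc(NC(=O)c4nn(-c5ccccc5C(F)(F)F)c(=O)cc4C)cc3F)ccnc2cc1OCCCN1CCN(C)CC1` gives 40 nM
compound 3 `COc1cc2c(Oc3ccc(NC(=O)c4nn(-c5cccc(F)c5)c(=O)cc4C)cc3F)ccnc2cc1OCCCN1CCCC1` gives 120 nM

Compound 3 stands second highest of the three numbers in this assay: compound 2 sits below it, compound 1 well above it. Among the measured compounds shown here, the one step measured so far, a 41-fold lower number from compound 1 to compound 2 (1.61 log units; beyond the scatter), concerns a substituent on the aromatic ring at the other end of the shared core.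

Compound 4 `COc1cc2c(Oc3ccc(NC(=O)c4nn(-c5cccc(F)c5)c(=O)cc4C)cc3F)ccnc2cc1OCCCN1CCN(C)CC1` differs from compound 3 only in the amine at the end of the chain: 4-methylpiperazin-1-yl in place of pyrrolidin-1-yl on a saturated chain carbon, three bonds along the chain from an oxygen on an aromatic ring. For the measured compounds named here, no measured pair shows this change, and the step from compound 1 to compound 2 does not touch that part of the molecule. With nothing pointing either way, the expectation is a step from compound 3 to compound 4 of no change at the digits printed from compound 3 to compound 4 (within the scatter), not beyond the scatter. Compound 4 is therefore estimated at 120 nM in this assay, within 45 nM to 320 nM.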

Compound 4, half-maximal inhibitory concentration: 120 nM
Beside the measured number, compound 4's estimate shows no gap at the digits printed; low and high end bracket the measured number.
By their numbers in this assay, from the lowest: compound 2; then compounds 3 and 4 (each within the scatter of the next); then compound 1.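

In this assay, the swap of pyrrolidin-1-yl for 4-methylpiperazin-1-yl at the end of the chain shows no change at the digits printed from compound 3 to compound 4 (within the scatter) with 3-fluorophenyl on the aromatic nitrogen, so the two amines read alike at this position. With the 3-(4-methylpiperazin-1-yl)propyl chain held fixed, the aromatic nitrogen substituent now has three members: 3-fluorophenyl gives a 3.0-fold higher number from compound 2 to compound 4 (0.48 log units; beyond the scatter) against 2-(trifluoromethyl)phenyl and a 14-fold lower number from compound 1 to compound 4 (1.13 log units; beyond the scatter) against 2-methylphenyl.

On these data alone, whether the two amines also read alike with either of those other aryl groups stays open. So does the outcome with a morpholine or a dimethylamino group at the chain end, or with a shorter chain. No evidence at hand speaks to the cause of these steps.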